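The source may hold more compounds than are shown below. What is called first, only, known or untested is meant among the compounds shown, and "the series" means these compounds.

Two compounds that share one core differ only in what sits on an oxygen on an aromatic ring. Compound 1 `O=c1[nH]c(-c2ccccc2O)nc2c1cnn2-c1ccc(Br)cc1` carries a hydrogen there, and in a functional assay on corpus cavernosum (Rattus norvegicus) for activation (a lower number here means a smaller maximal response, a higher number a larger maximal response), compound 1 reaches 167%. Compound 2 `CCCOc1ccccc1-c1nc2c(cnn2-c2ccc(Br)cc2)c(=O)[nH]1` carries a propyl on that oxygen, and in this assay compound 2 reaches 140%. The step between them is a number 27 percentage points lower from compound 1 to compound 2 (beyond the scatter). Among the two numbers so far, compound 2 stands lowest, with compound 1 as its nearest neighbour, higher by an amount beyond the scatter.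

Compound 3 `CCCCOc1ccccc1-c1nc2c(cnn2-c2ccc(Br)cc2)c(=O)[nH]1` has not yet been measured. It differs from compound 2 in one place: methyl in place of hydrogen on a saturated chain carbon, three bonds along the chain from an oxygen on an aromatic ring. Among the measured compounds shown here, only one measured step bears on this change: the modest drop a number 27 percentage points lower from compound 1 to compound 2 (beyond the scatter) came with a propyl replacing a hydrogen, while here a methyl is added to the end of a chain that is already present, a smaller alteration. A smaller step in this assay is therefore expected, either downward or none beyond the scatter. Compound 3 is estimated to give 130%, in a range from 108% to 155%, which would be an expected step of a number 10 percentage points lower from compound 2 to compound 3 (within the scatter).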

Compound 3, largest response reached (Emax), in percent of the reference or control that the assay uses: 160%
Compound 3: the middle estimate sits 30 percentage points below what was measured; measured number above the stated range.
By their numbers in this assay, from the lowest: compound 2; then compounds 3 and 1 (each within the scatter of the next).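

In this assay adding one methyl on a saturated chain carbon, three bonds along the chain from an oxygen on an aromatic ring, gives a number 20 percentage points higher from compound 2 to compound 3 (beyond the scatter) and shows that a change this small, this far along the chain, can still move the response beyond the scatter. Among the compounds shown here, replacing the hydrogen on that oxygen with butyl gives a number 7 percentage points lower from compound 1 to compound 3 (within the scatter) so a chain on this oxygen does not by itself lower the response; compound 2, with its propyl, is the one compound that goes against this, and the response does not move in one direction across hydrogen, propyl and butyl. Nothing available here accounts for this turn in the response.

Three compounds cannot tell whether the lower response of the propyl is an isolated dip or part of a more complex trend with chain length, and a longer chain such as pentyl or hexyl would test this. They also leave open how the response would change with an amine or a carboxylic acid on that chain, or with a branched chain such as isobutyl in place of butyl.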